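The compounds below may be only part of what the source reports. "The series", "measured", "known", "first", "only" and "open" are said of these compounds alone.

Compound 3 `COc1cccc(NC(=O)CSc2nnc(-c3cc(OC)c(OC)c(OC)c3)n2N)c1` carries a (3-methoxyphenyl)amino group on the carbonyl carbon of the shared core. In a functional assay on PC-3 cells (Homo sapiens) for antiproliferative activity, read by MTT assay, with a stated time of 48 h (a higher number here means a weaker inhibitor, a lower number a stronger inhibitor), compound 3 gives only a limit, > 100000 nM. Compound 1 `COc1cc(-c2nnc(SCC(=O)c3ccc(Br)cc3)n2N)cc(OC)c1OC` likewise gives only a limit in this assay, > 100000 nM. Compound 2 `COc1ccc(C(=O)CSc2nnc(-c3cc(OC)c(OC)c(OC)c3)n2N)cc1` gives 97900 nM in this assay. The steps of an at least 1.0-fold lower number from compound 1 to compound 2 (0.00 log units; that floor lies within the scatter) and an at least 1.0-fold higher number from compound 2 to compound 3 (0.00 log units; that floor lies within the scatter) stay within the scatter, while a step that the two limits leave unreadable from compound 1 to compound 3 cannot be read, since two of the three values sit at the limit of > 100000 nM in this assay, at which 2 of the 3 values shown sit. Compound 4 `COc1cc(-c2nnc(SCC(=O)Nc3ccccc3F)n2N)cc(OC)c1OC` differs from compound 3 by 2-fluorophenyl in place of 3-methoxyphenyl on an amide-type nitrogen. The measured steps show no movement beyond the scatter. Compound 4 is therefore expected to stay near the limit, with a number no higher from compound 3 to compound 4 (the limit leaves the size open) estimated as no step beyond the scatter. The estimate for compound 4 in this assay is 100000 nM, between 50000 nM and 300000 nM.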

Compound 4, half-maximal inhibitory concentration: 36700 nM
The estimate for compound 4 lay 2.7-fold (0.44 log units) above the measured number, and the stated range ends above it.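

Putting 2-fluorophenyl in place of 3-methoxyphenyl on the amide-type nitrogen gave, in this assay, an at least 2.7-fold lower number from compound 3 to compound 4 (0.43 log units; beyond the scatter) and so, unlike any earlier step, moved beyond the scatter. The (2-fluorophenyl)amino group also gave a 2.7-fold lower number from compound 2 to compound 4 (0.43 log units; beyond the scatter) and an at least 2.7-fold lower number from compound 1 to compound 4 (0.43 log units; beyond the scatter), which sets compound 4 apart from all three earlier compounds. The steps from compound 3 and from compound 1 are only floors because both compounds give limits: the limit of > 100000 nM in this assay, at which 2 of the 4 values shown sit.

The compounds shown leave open whether losing the methoxy or gaining the fluoro drives this step. They also leave open whether plain phenyl or 2-chlorophenyl on the same nitrogen would keep it.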